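The compounds below may be only part of what the source reports. "The series", "measured", "known", "first", "only" and "open" are said of these compounds alone.

Compound 3 `CCc1cccc(Nc2cc(NC(=O)Nc3cc(OC)cc(OC)c3)ncn2)c1` gives 23% in a functional assay on NCI-H520 cells (Homo sapiens) for inhibition, read by MTT assay, with a stated time of 48 h, tested at 10 uM (a higher number here means more inhibition at the concentration tested (going by the name of the read-out), a lower number less inhibition), the lowest of the three measured numbers, with compound 1 `COc1cc(NC(=O)Nc2cc(Nc3cc(Br)ccc3OC)ncn2)cc(OC)c1` at 43.5% and compound 2 `COc1ccc(OC)c(Nc2cc(NC(=O)Nc3c(Cl)cccc3Cl)ncn2)c1` at 74% both clearly higher. Compound 4 `COc1cc(NC(=O)Nc2cc(Nc3cc(C)cc(F)c3)ncn2)cc(OC)c1` differs from compound 3 in one place: 3-fluoro-5-methylphenyl in place of 3-ethylphenyl on a nitrogen on an aromatic ring. Going by the values given here, the only measured step that bears on this change is a number 20.5 percentage points lower from compound 1 to compound 3 (beyond the scatter), which also swapped one ring on that same nitrogen for another; no measured pair shows a fluorine or methyl group on this ring. Some movement in this assay is therefore plausible, but its direction is not settled by the data, and the expected step is a number 9 percentage points higher from compound 3 to compound 4 (within the scatter), modest and upward. Compound 4 is estimated at 32%, with a range from 10% to 58%.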

Compound 4, a percentage reported as inhibition, at one concentration (the size of the read-out at that concentration, not a potency): 24.5%
Beside the measured number, compound 4's estimate is 7.5 percentage points above it; measured number inside the range.
By their numbers in this assay, from the lowest: compounds 3 and 4 (each within the scatter of the next); then compound 1; then compound 2.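

In this assay, 3-fluoro-5-methylphenyl in place of 3-ethylphenyl on this nitrogen gives a number 1.5 percentage points higher from compound 3 to compound 4 (within the scatter), so these two rings, with the same number of heavy atoms, cannot be told apart here. Measured against 5-bromo-2-methoxyphenyl, the step is a number 19 percentage points lower from compound 1 to compound 4 (beyond the scatter), so the earlier gap, a number 20.5 percentage points lower from compound 1 to compound 3 (beyond the scatter), is not peculiar to 3-ethylphenyl. Nothing available explains these numbers.

Still open, from the compounds shown here alone, is whether an amine or a carboxylic acid on this ring would move the number. The compounds shown also do not separate the bromine from the methoxy group of 5-bromo-2-methoxyphenyl.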